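Methoxy in Place of Chloro, Tested a Second Time

This account rests on a few compounds, and the source may have more. Where it says the series, first, only, none or still open, it means among the compounds named here.

Compound 1 `O=C(Nc1nc2ccc(Cl)cc2s1)c1cn(-c2ccccc2)nc1-c1ccccc1`: 7810 nM
Compound 2 `COc1ccc2nc(NC(=O)c3cn(-c4ccccc4)nc3-c3ccccc3)sc2c1`: > 50000 nM, a limit of the assay
Compound 3 `O=C(Nc1nc2ccccc2s1)c1cn(-c2ccccc2)nc1-c1ccc(Cl)cc1`: 13700 nM

In a functional assay on HT-29 cells (Homo sapiens) for cytotoxicity, read by MTT assay, with a stated time of 72 h (on this read-out lower numbers stand for stronger inhibition and higher numbers for weaker inhibition), compound 1 gives 7810 nM. For compound 2 the assay reports only a limit, (the limit of > 50000 nM in this assay, at which 1 of the 3 values shown sits). The change methoxy in place of chloro on an aromatic carbon thus produced an at least 6.4-fold higher number from compound 1 to compound 2 (0.80 log units; beyond the scatter). Compound 3 and compound 1 share the same atoms joined differently; the difference between the two cores is not broken down here. Compound 3 gives 13700 nM.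

Compound 4 `COc1ccc(-c2nn(-c3ccccc3)cc2C(=O)Nc2nc3ccccc3s2)cc1` carries the same kind of change, (methoxy in place of chloro on an aromatic carbon). Around the place the two cases differ: in compound 1 the chloro sits on a ring that is part of a fused system, meta and para to a fused ring, whereas in compound 3 it sits on a six-membered aromatic ring of carbon only, para to a large group. Resting on an at least 6.4-fold higher number from compound 1 to compound 2 (0.80 log units; beyond the scatter), a weakening step is expected from compound 3 to compound 4, a 2.6-fold higher number from compound 3 to compound 4 (0.41 log units; beyond the scatter), though the different place leaves its size uncertain. Compound 4 is estimated at 35000 nM, between 12000 nM and 100000 nM.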

Compound 4, half-maximal inhibitory concentration: 10500 nM
For compound 4 the middle estimate is 3.3-fold (0.52 log units) above the measured one, outside the stated range (below it).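

In this assay the change of chloro to methoxy gave a 1.3-fold lower number from compound 3 to compound 4 (0.12 log units; within the scatter), so the step seen on the core of compound 1 did not carry over to the core of compound 3: the same change on two cores in this assay, an at least 6.4-fold higher number (0.80 log units; beyond the scatter) from compound 1 to compound 2 and a 1.3-fold lower number (0.12 log units; within the scatter) from compound 3 to compound 4, at least 8.3-fold (0.92 log units) apart, beyond the scatter of two such steps

Compound 2 stands at > 50000 nM, which is a limit of the assay and not a number. These two pairs show that the change does not move as a fixed step between these two cores, but they do not show why the steps differ or what the change would do on any further core.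

The compounds shown leave open what an amine or a carboxylic acid would do in place of the chloro of the 4-chlorophenyl group. They also leave open whether a longer chain on the oxygen would keep the number of compound 4 where it stands.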